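The source may hold more compounds than are shown below. What is called first, only, known or untested is meant among the compounds shown, and "the series" means these compounds.

Measured so far:
- Compound 1 `CC(C)[C@H](NC(=O)COc1cccc2ccccc12)C(=O)N[C@@H](CC(=O)O)C(=O)COc1cccc2ccccc12`; in a functional assay on Jurkat cells (Homo sapiens) (a higher number here means a weaker inhibitor, a lower number a stronger inhibitor), compound 1 gives > 100000 nM, a limit of the assay rather than a number.
- Compound 2 `CC(C)[C@H](NC(=O)COc1cccc2ccccc12)C(=O)N[C@@H](CC(=O)O)C(=O)COc1ccc(C(N)=O)cc1`; in this assay compound 2 gives > 100000 nM, again only a limit.

Among the compounds with values here, compound 1 therefore stands nowhere on a numerical scale in this assay: its value is a limit, and the one other value is a limit too, both sitting at the limit of > 100000 nM in this assay, at which 2 of the 2 values shown sit.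

The compound to be measured is compound 3 `CC(C)[C@H](NC(=O)COc1cccc2ccccc12)C(=O)N[C@@H](CC(=O)O)C(=O)COc1ccc(F)c(F)c1`. The change from compound 1 is 3,4-difluorophenyl in place of naphthalen-1-yl on an oxygen on a saturated carbon.

Within the data shown here, the only measured step that touches this position is a step that the two limits leave unreadable from compound 1 to compound 2, which replaces the same naphthalen-1-yl on the same oxygen with 4-carbamoylphenyl. Its size cannot be read, since both of its ends rest at the limit of > 100000 nM in this assay, at which 2 of the 2 values shown sit. Nothing in the series therefore shows whether a smaller aromatic group at this place moves the read-out at all, in either direction.

On this basis no step beyond the scatter is expected from compound 1 to compound 3, a number no higher from compound 1 to compound 3 (the limit leaves the size open), and the result is most likely to be reported as a limit again. Compound 3 is estimated at 100000 nM, within a range of 30000 nM to 300000 nM.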

Compound 3, half-maximal inhibitory concentration: > 100000 nM
Compound 3 ended at the assay's limit; the forecaster's own chance of this, stated with the estimate: 80%; the middle value lies on the limit itself.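

No step can be read among compound 1, compound 2 and compound 3 in this assay, as all three values are limits and not numbers, and all rest at the same one: the limit of > 100000 nM in this assay, at which 3 of the 3 values shown sit.

The compounds shown leave open whether any of the naphthalen-1-yl, 4-carbamoylphenyl or 3,4-difluorophenyl groups on this oxygen changes the read-out, and in which direction.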